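Ortho Hydroxy in Place of Methyl on the Thiosemicarbazone Aryl

A few compounds are considered here, and "the series" means these few. Any claim that something is new, unique, unknown or untested is made for them only; others in the source may bear on it.

Compound 1 `Oc1ccc(/C=N/NC(=S)Nc2ccc(Cl)cc2)cc1`: 287000 nM
Compound 2 `Cc1ccccc1NC(=S)N/N=C/c1ccc(O)cc1`: 36500 nM
Compound 3 `Cc1ccc(NC(=S)N/N=C/c2ccc(O)cc2)cc1`: 14200 nM

In an assay for inhibition of ribonucleoside-diphosphate reductase RR1 (Homo sapiens), with a stated time of 30 min (a higher number here means a weaker inhibitor, a lower number a stronger inhibitor), compound 2 gives the second highest of the three numbers, with compound 3 nearer to it and compound 1 furthest away. Compound 4 `Oc1ccc(/C=N/NC(=S)Nc2ccccc2O)cc1` differs from compound 2 by hydroxy in place of methyl on an aromatic carbon. Within the data shown here, no measured step changes a methyl into a hydroxy. Among the measured compounds shown here, the one step measured on this aryl ring, a 20-fold lower number from compound 1 to compound 3 (1.31 log units; beyond the scatter), is large, so a substituent change here can shift this assay markedly, but its direction for hydroxy cannot be read from it. A moderate change in either direction is therefore expected, a 1.2-fold lower number from compound 2 to compound 4 (0.09 log units; within the scatter), and compound 4 is estimated at 30000 nM, within 7000 nM to 130000 nM.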

Compound 4, half-maximal inhibitory concentration: 29300 nM
Compound 4: the middle estimate sits 1.0-fold (0.01 log units) above what was measured; the measured number falls inside the stated range.
By their numbers in this assay, from the lowest: compound 3; then compounds 4 and 2 (each within the scatter of the next); then compound 1.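

In this assay, hydroxy in place of methyl on an aromatic carbon, ortho to a large group, gives a 1.2-fold lower number from compound 2 to compound 4 (0.10 log units; within the scatter), so this assay does not separate the two groups at this place. Although the earlier step on this ring was large, this change, which brings in a hydrogen-bond donor and a hydrogen-bond acceptor, stays within the scatter. Nothing available explains this result. Open, on these data alone, is whether an amine or a carboxylic acid at this place would also leave the number within the scatter of compound 2 and compound 4.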